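Fused-ring substituent change: ethoxy to trifluoromethyl

A few compounds are considered here, and "the series" means these few. Any claim that something is new, unique, unknown or untested is made for them only; others in the source may bear on it.

Measured so far, in a functional assay on Hep 3B2 cells (Homo sapiens) for antiproliferative activity, read by MTT assay, with a stated time of 24 h, tested at 0.41 ug/mL; a higher number here means a stronger effect of the compound at the concentration tested, a lower number a weaker effect:
compound 1 `CCc1ccc2nc(C(=O)Nc3c(F)cc(-c4cccc(F)c4)cc3F)c(C)c(O)c2c1` gives 16.2%
compound 2 `CCOc1ccc2nc(C(=O)Nc3c(F)cc(-c4cccc(F)c4)cc3F)c(C)c(O)c2c1` gives 0.26%

Among the compounds with values here, compound 2 stands lowest of the two numbers in this assay, with compound 1 its only neighbour; the step of a number 15.9 percentage points lower from compound 1 to compound 2 (beyond the scatter) separates them.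

Compound 3 `Cc1c(C(=O)Nc2c(F)cc(-c3cccc(F)c3)cc2F)nc2ccc(C(F)(F)F)cc2c1O` differs from compound 2 by trifluoromethyl in place of ethoxy on an aromatic carbon. Within the data shown here, only one measured step exists, the one from compound 1 to compound 2, and it concerns the ethoxy group that leaves here, not the trifluoromethyl group that enters, so it bears on the change only indirectly. That step, a number 15.9 percentage points lower from compound 1 to compound 2 (beyond the scatter), shows that a group change at this carbon can move the read-out by a modest amount. Without a direct precedent for trifluoromethyl, a step of a number 9.7 percentage points higher from compound 2 to compound 3 (within the scatter) upward from compound 2 is expected in this assay, uncertain in size. Compound 3 is therefore estimated at 10%, with a range from 0% to 30%.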

Compound 3, a percentage reported as inhibition, at one concentration (the size of the read-out at that concentration, not a potency): 9.38%
The estimate for compound 3 lay 0.6 percentage points above the measured number; low and high end bracket the measured number.
By their numbers in this assay, from the lowest: compounds 2, 3 and 1 (each within the scatter of the next, the first and the last beyond it).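

In this assay trifluoromethyl on this aromatic carbon gives a number 9.1 percentage points higher from compound 2 to compound 3 (within the scatter) and also a number 6.8 percentage points lower from compound 1 to compound 3 (within the scatter), so it cannot be told apart from either ethoxy or ethyl. Within the data shown here, the only step beyond the scatter at this carbon therefore remains the one between ethyl and ethoxy, a number 15.9 percentage points lower from compound 1 to compound 2 (beyond the scatter), and the trifluoromethyl compound adds no second separation and no clear order among the three groups. Nothing measured here accounts for any of these steps.

As far as these compounds go, whether an amine, a carboxylic acid or a longer alkyl chain on this carbon would move the read-out beyond the scatter of all three compounds remains open. From the compounds shown here alone, each read-out is also the size of the effect at one concentration, so the relative potency of the three compounds remains open too.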